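The source may hold more compounds than are shown below. What is called first, only, known or untested is meant among the compounds shown, and "the series" means these compounds.

Values in an ADME assay on HEK293 cells (Homo sapiens) for cytotoxicity, with a stated time of 72 h (a higher number here means that more compound is needed for the effect, a lower number that less compound is needed), so far
Compound 1 (`Cc1cc(NC(=O)Nc2ccccc2C(C)(C)C)c2ccccc2n1`) gives > 25000 nM as a limit
Compound 2 (`Cc1cc(NC(=O)Nc2ccc(OC(F)(F)F)cc2)c2ccccc2n1`) gives 14000 nM

Compound 1 stands on a limit of this assay and has no number (the limit of > 25000 nM in this assay, at which 1 of the 2 values shown sits). Compound 3 (`Cc1cc(NC(=O)Nc2ccccc2[N+](=O)[O-])c2ccccc2n1`) differs from it by nitro in place of tert-butyl on an aromatic carbon, ortho to a large group on a six-membered aromatic ring of carbon only. Among the compounds with values here, no step between measured compounds is available to size this change, so the expectation rests on the two values alone. Compound 2 gives 14000 nM and shows that a number can be read in this range. A modest step toward less compound needed is expected (an at least 1.2-fold lower number from compound 1 to compound 3 (0.09 log units; that floor lies within the scatter)), though a result again on the limit is quite possible. For compound 3 the estimated value is 20000 nM with an expected range (9000 nM to 35000 nM).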

Compound 3, half-maximal effective concentration: > 25000 nM
Compound 3: only a limit was reported; the forecaster's own chance of this, stated with the estimate: 45%; middle value at least 1.2-fold (0.09 log units) from the limit.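

Compound 1 and compound 3 both give only a limit in this assay, so no step can be read between them: the limit of > 25000 nM in this assay, at which 2 of the 3 values shown sit.

The compounds shown leave open how much nitro in place of tert-butyl on an aromatic carbon changes the amount of compound needed in this assay.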